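The compounds below may be only part of what the source reports. "The series", "measured", "known", "first", "only" and "open" are said of these compounds alone.

Measured so far:
Compound 1, `Cc1[nH]c2ccccc2c1C(C1=C(O)C(=O)c2ccccc2C1=O)c1ccc(Cl)cc1`: in a toxicity assay (Homo sapiens) for cytotoxicity, read by MTT assay, with a stated time of 48 h (a lower number here means a stronger inhibitor, a higher number a weaker inhibitor), compound 1 gives 40300 nM.
Compound 2, `O=C1C(O)=C(C(c2ccc([N+](=O)[O-])cc2)c2c[nH]c3ccccc23)C(=O)c2ccccc21`: in this assay compound 2 gives > 200000 nM.

Compound 2 stands at the edge of what this assay can report: its value of > 200000 nM is a limit of the assay and not a number. Of the two values shown, one sits at that limit (the limit of > 200000 nM in this assay, at which 1 of the 2 values shown sits), and only compound 1 gives a reading that can be placed on the scale.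

Compound 3, `Cc1[nH]c2ccccc2c1C(C1=C(O)C(=O)c2ccccc2C1=O)c1ccc([N+](=O)[O-])cc1`, is not yet measured. It differs from compound 2 in one place: methyl in place of hydrogen on an aromatic carbon. Compound 1 also carries this methyl, with a chloro group where compound 3 has the nitro group. For the measured compounds named here, no step between measured compounds isolates the methyl, so the expectation rests on little. The estimated step is an at least 1.6-fold lower number from compound 2 to compound 3 (0.22 log units; that floor lies within the scatter), toward a stronger inhibitor, though a limit may again be all the assay reports. For compound 3 the expected value is 120000 nM, with a range from 40000 nM to 250000 nM.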

Compound 3, half-maximal inhibitory concentration: 15100 nM
For compound 3 the middle estimate is 7.9-fold (0.90 log units) above the measured one; measured number outside the range, below it.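

With the nitro group kept, methyl in place of hydrogen on the aromatic carbon next to the ring nitrogen, which turns 1H-indol-3-yl into 2-methyl-1H-indol-3-yl, gives an at least 13-fold lower number from compound 2 to compound 3 (1.12 log units; beyond the scatter) in this assay and brings the compound from the limit onto the readable scale. With that methyl kept, nitro in place of chloro gives a 2.7-fold lower number from compound 1 to compound 3 (0.43 log units; beyond the scatter) so the group at the other end also changes the reading, though less clearly than the methyl does. The methyl step is only a floor, as compound 2 has a limit and not a number: the limit of > 200000 nM in this assay, at which 1 of the 3 values shown sits.

The compounds shown leave open whether methyl acts the same way with chloro in place of nitro, and whether an ethyl group at this position would go further. Also open, from the compounds shown here alone, is what an amine or a carboxylic acid in place of the nitro group would do to the reading.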